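Nitro substitution on the anilide ring of vinyl sulfonamides

The source may hold more compounds than are shown below. What is called first, only, known or untested is meant among the compounds shown, and "the series" means these compounds.

Three compounds of this series have numbers in a functional assay on DU-145 cells (Homo sapiens) for cytotoxicity, read by trypan blue exclusion, with a stated time of 96 h; a higher number here means a weaker inhibitor, a lower number a stronger inhibitor. Compound 3 `COc1ccc(NS(=O)(=O)/C=C/c2c(F)c(F)c(F)c(F)c2F)cc1` gives 10000 nM. Compound 1 `COc1ccc(NS(=O)(=O)/C=C/c2c(F)c(F)c(F)c(F)c2F)cc1[N+](=O)[O-]` gives 100000 nM. Compound 2 `COc1ccc(NS(=O)(=O)/C=C/c2cc(OC)c(OC)c(OC)c2)cc1` gives 35000 nM. The change from compound 3 to compound 1 is nitro in place of hydrogen on an aromatic carbon, and it moved the number by a 10-fold higher number from compound 3 to compound 1 (1.00 log units; beyond the scatter). How the core of compound 2 differs from that of compound 3 is not broken down here. Compound 4 `COc1ccc(NS(=O)(=O)/C=C/c2cc(OC)c(OC)c(OC)c2)cc1[N+](=O)[O-]` carries the same kind of change on the core of compound 2, namely (nitro in place of hydrogen on an aromatic carbon), with the same surroundings at the place. The expectation for compound 4 rests on the step seen from compound 3 to compound 1, a 10-fold higher number from compound 3 to compound 1 (1.00 log units; beyond the scatter), applied to compound 2 at 35000 nM. Compound 4 is therefore expected to give a step of a 2.9-fold higher number from compound 2 to compound 4 (0.46 log units; beyond the scatter), a weaker effect than the earlier one because compound 2 already starts at 35000 nM. Compound 4 is estimated at 100000 nM, with a range of 35000 nM to 350000 nM.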

Compound 4, half-maximal inhibitory concentration: 75000 nM
Beside the measured number, compound 4's estimate is 1.3-fold (0.12 log units) above it, within the range that was stated.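

In this assay the new step is a 2.1-fold higher number from compound 2 to compound 4 (0.33 log units; beyond the scatter) and so nitro in place of hydrogen on an aromatic carbon gives a higher number on both cores shown. The direction of the change carries from one core to the other, but its size does not: the same change on two cores in this assay, a 10-fold higher number (1.00 log units; beyond the scatter) from compound 3 to compound 1 and a 2.1-fold higher number (0.33 log units; beyond the scatter) from compound 2 to compound 4, 4.7-fold (0.67 log units) apart, beyond the scatter of two such steps.
Two pairs do not show what sets the size of the step, nor how the change would behave on any further core.

Still open, as far as these compounds go, is whether an amine or a carboxylic acid in place of the nitro would move the number in the same direction. Also open, from the compounds shown here alone, is whether a nitrile at that place would give a step closer to that on one core or the other.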